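The source may hold more compounds than are shown below. What is called first, only, known or untested is meant among the compounds shown, and "the series" means these compounds.

Going by the values given here, compound 1 `Cc1cc(S(=O)(=O)/N=C(\N)n2nccc2-c2ccccc2)c(SCc2ccccc2)cc1Cl` is one of three compounds measured in a functional assay on HCT-116 cells (Homo sapiens) for cytotoxicity, read by MTT assay, with a stated time of 72 h (a higher number here means a weaker inhibitor, a lower number a stronger inhibitor), where compound 1 gives 12000 nM. Compound 2 `Cc1cc(-c2ccccc2)n(/C(N)=N/S(=O)(=O)c2cc(C)c(Cl)cc2SCc2ccccc2)n1` gives 10000 nM, and the step of a 1.2-fold lower number from compound 1 to compound 2 (0.08 log units; within the scatter) stays within the scatter, so the two numbers cannot be ordered. Compound 3 `Cc1cc(-c2ccccc2)n(/C(N)=N/S(=O)(=O)c2cc(C)c(Cl)cc2SCc2ccccc2C)n1` gives 42000 nM, which is higher than the number of compound 1 by more than the scatter, so among the three, compound 1 sits second highest.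

Compound 4 `Cc1cc(S(=O)(=O)/N=C(\N)n2nccc2-c2ccccc2)c(SCc2cccc(C(F)(F)F)c2)cc1Cl` differs from compound 1 by a single change: trifluoromethyl in place of hydrogen on an aromatic carbon. Among the compounds with values here, no measured step introduces a trifluoromethyl group, so the expectation rests on the two steps that put a methyl on an aromatic carbon. The step of a 1.2-fold lower number from compound 1 to compound 2 (0.08 log units; within the scatter) changed nothing beyond the scatter, while the step of a 4.2-fold higher number from compound 2 to compound 3 (0.62 log units; beyond the scatter) gave a modestly higher number, that is, a weaker inhibitor. A substituent entering an aromatic ring of this series has therefore been either neutral or modestly unfavourable in this assay, and the larger group now entering is expected to behave like the second case.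

On that basis compound 4 is expected to give 25000 nM, within a range of 9000 nM to 70000 nM, a step of a 2.1-fold higher number from compound 1 to compound 4 (0.32 log units; beyond the scatter) toward a weaker inhibitor.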

Compound 4, half-maximal inhibitory concentration: 14000 nM
For compound 4 the middle estimate is 1.8-fold (0.25 log units) above the measured one; low and high end bracket the measured number.
By their numbers in this assay, from the lowest: compounds 2, 1 and 4 (each within the scatter of the next); then compound 3.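

In this assay the change from benzylsulfanyl to (3-(trifluoromethyl)benzyl)sulfanyl gives a 1.2-fold higher number from compound 1 to compound 4 (0.07 log units; within the scatter) and thus shows that this carbon of the benzyl ring takes a trifluoromethyl group, with its 4 heavy atoms, without a change that can be read. A substituent on the benzyl ring therefore does not by itself go with a higher number: the only earlier case on that ring, a 4.2-fold higher number from compound 2 to compound 3 (0.62 log units; beyond the scatter), was beyond the scatter, but it differs from the new step in the group, in the carbon it occupies and in the parent compound, so the two steps cannot be set against each other as a single trend. The information at hand gives no measured basis for explaining either outcome.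

The compounds shown leave open whether an amine or a carboxylic acid on this same carbon would move the number in this assay beyond the scatter, in either direction. They also leave open whether trifluoromethyl would again make no readable difference if it were placed on the benzyl ring of compound 2, which carries the additional methyl.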